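Replacing a Hydroxypropyl Chain with a Trifluoromethylphenyl Group

The source may report more compounds than this note shows. Statements on the series, on what has been measured and on what is new or still open speak of the compounds shown alone.

Compound 1 `COc1nc2ccc(Br)cc2cc1C(c1ccccc1)n1cc(C2CC2)nn1`, compound 2 `CCCCCCCCc1cn(C(c2ccccc2)c2cc3cc(Br)ccc3nc2OC)nn1` and compound 3 `COc1nc2ccc(Br)cc2cc1C(c1ccccc1)n1cc(CCCO)nn1` share one core and differ only in the group on an aromatic carbon. In an ADME assay on PANC-1 cells (Homo sapiens) for cytotoxicity, read by sulforhodamine B assay, with a stated time of 48 h, tested at 10 uM (on this read-out higher numbers stand for more inhibition at the one concentration tested (going by the name of the read-out) and lower numbers for less inhibition), compound 1 gives 21.8%, compound 2 gives 12.1% and compound 3 gives 25.5%. Compound 3 stands highest of the three, though the gap to compound 1 lies within the scatter, while a number 13.4 percentage points higher from compound 2 to compound 3 (beyond the scatter) and a number 9.7 percentage points lower from compound 1 to compound 2 (within the scatter) frame the range. Compound 4 `COc1nc2ccc(Br)cc2cc1C(c1ccccc1)n1cc(-c2ccccc2C(F)(F)F)nn1` carries 2-(trifluoromethyl)phenyl in place of 3-hydroxypropyl on an aromatic carbon. The step from compound 2 to compound 3 bears most, since the hydroxy group now leaves again; the step from compound 1 to compound 2 suggests a larger group at that carbon brings no gain. A modest drop is therefore expected, a number 11.5 percentage points lower from compound 3 to compound 4 (beyond the scatter), and compound 4 is estimated at 14%, between 3% and 27%.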

Compound 4, a percentage reported as inhibition, at one concentration (the size of the read-out at that concentration, not a potency): 11.4%
The estimate for compound 4 lay 2.6 percentage points above the measured number; measured number inside the range.
By their numbers in this assay, from the lowest: compounds 4, 2, 1 and 3 (each within the scatter of the next, the first and the last beyond it).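

In this assay the 2-(trifluoromethyl)phenyl group gives a number 14.1 percentage points lower from compound 3 to compound 4 (beyond the scatter) and a number 10.4 percentage points lower from compound 1 to compound 4 (beyond the scatter) but a number 0.7 percentage points lower from compound 2 to compound 4 (within the scatter) so at this carbon it reads like the octyl chain. For the compounds shown here, it also adds something the octyl chain did not show, since only the step to this aromatic ring, not the step to octyl, is beyond the scatter from cyclopropyl. Nothing at hand explains these steps. Going by these compounds, whether the phenyl ring or its trifluoromethyl group carries the change stays open, and an unsubstituted phenyl group would separate them. Also open, on these data alone, is how an amine at the end of the propyl chain would compare with the hydroxy group of compound 3.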